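A Methoxy in Place of Methyl on Compound 1

The source may report more compounds than this note shows. Statements on the series, on what has been measured and on what is new or still open speak of the compounds shown alone.

In a functional assay, read by spectrophotometry, with a stated time of 20 min (a lower number here means a stronger inhibitor, a higher number a weaker inhibitor), compound 1 (`Cc1ccccc1-c1oc2ccccc2c(=O)c1C`) gives 156 ug/mL. Compound 2 (`COc1ccc2c(=O)c(C)c(-c3ccc(Cl)cc3)oc2c1`) gives 80.6 ug/mL, and compound 3 (`Cc1c(-c2ccc([N+](=O)[O-])cc2)oc2ccccc2c1=O`) gives 132 ug/mL, so compound 1 stands within the scatter of both. Compound 4 (`COc1ccccc1-c1oc2ccccc2c(=O)c1C`) has not yet been measured. It carries methoxy in place of methyl on an aromatic carbon, ortho to a large group (methoxy in place of methyl on an aromatic carbon). Within the data shown here, no two measured compounds differ in only one place, so no measured step guides this change. With compound 1 at 156 ug/mL as the anchor, no step beyond the scatter is expected in this assay. The expected step is a 1.2-fold lower number from compound 1 to compound 4 (0.06 log units; within the scatter). For compound 4, the estimated value is 135 ug/mL, with an expected range of 65 ug/mL to 270 ug/mL.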

Compound 4, half-maximal inhibitory concentration: 143 ug/mL
For compound 4 the middle estimate is 1.1-fold (0.03 log units) below the measured one, within the range that was stated.
By their numbers in this assay, from the lowest: compounds 2, 3, 4 and 1 (each within the scatter of the next).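

In this assay, among these compounds, the change gives the first step that can be read at this position, ortho to a large group: a 1.1-fold lower number from compound 1 to compound 4 (0.04 log units; within the scatter). Methoxy brings an oxygen and a hydrogen-bond acceptor that methyl lacks, yet the two compounds cannot be told apart in this assay. No independent evidence bears on why this is so. The compounds shown leave open whether an amine or a carboxylic acid at this place would give a step beyond the scatter. They also leave open whether a longer chain, such as ethoxy, would do so.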